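A few compounds are considered here, and "the series" means these few. Any claim that something is new, unique, unknown or untested is made for them only; others in the source may bear on it.

Measured so far:
- compound 1 `COc1cccc2[nH]cc(C3(c4c[nH]c5cccc(OC)c45)C(=O)Nc4ccccc43)c12`: 5000 nM
- compound 2 `COc1ccc2[nH]cc(C3(c4c[nH]c5ccc(OC)cc45)C(=O)Nc4ccccc43)c2c1`: 2200 nM
- compound 3 `O=C1Nc2ccc(F)cc2C1(c1c[nH]c2ccccc12)c1c[nH]c2ccccc12`: 12800 nM

In a functional assay on DU-145 cells (Homo sapiens) for cytotoxicity, read by MTT assay, with a stated time of 48 h (a lower number here means a stronger inhibitor, a higher number a weaker inhibitor), compound 1 gives 5000 nM, the second highest of the three numbers. Its nearest neighbour is compound 2, which in this assay gives 2200 nM, lower by a margin beyond the scatter. Compound 3, which carries no methoxy groups but does carry a fluoro, gives 12800 nM, higher than compound 1 by a margin also beyond the scatter. No pair among these three differs in only one place, so no single-change step can be read off.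

Compound 4 `COc1cccc2[nH]cc(C3(c4c[nH]c5cccc(OC)c45)C(=O)Nc4ccc(F)cc43)c12` is not yet measured. It differs from compound 1 by fluoro in place of hydrogen on an aromatic carbon. Nothing measured isolates this change; compound 3 carries a fluoro but also lacks both methoxy groups, so its higher number cannot be read as the effect of the fluoro alone. The expected step from compound 1 to compound 4 is small, a 1.3-fold higher number from compound 1 to compound 4 (0.11 log units; within the scatter), leaning toward a weaker inhibitor but not clearly beyond the scatter. Compound 4 is expected to give about 6500 nM in this assay, within a range from 2500 nM to 16000 nM.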

Compound 4, half-maximal inhibitory concentration: 9400 nM
For compound 4 the middle estimate is 1.4-fold (0.16 log units) below the measured one; the measured number falls inside the stated range.
By their numbers in this assay, from the lowest: compound 2; then compounds 1, 4 and 3 (each within the scatter of the next, the first and the last beyond it).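

In this assay, the series now has its first single-change step: fluoro in place of hydrogen on an aromatic carbon, meta to a fused ring and para to a fused ring, gives a 1.9-fold higher number from compound 1 to compound 4 (0.27 log units; within the scatter). With both methoxy groups held constant, the fluoro at this position therefore produces no change beyond the scatter, which compound 3 could not show, as it carries the fluoro but lacks both methoxy groups. Nothing available gives a cause for the size of this step.

The compounds shown leave open whether the fluoro step would read the same on the core without methoxy groups, or with those groups placed as in compound 2. They also leave open how larger or different groups at this same carbon, such as a chloro, a methoxy, an amine or a carboxylic acid, would compare with hydrogen and fluoro, so the tolerance of this position is established for the fluoro alone and only on the core of compound 1.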